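The source may hold more compounds than are shown below. What is called first, only, known or untested is meant among the compounds shown, and "the series" means these compounds.

In a functional assay on PC-3 cells (Homo sapiens) for cytotoxicity, read by MTT assay, with a stated time of 48 h (a higher number here means a weaker inhibitor, a lower number a stronger inhibitor), compound 1 `COc1cc(-c2nnc3n2NC(c2ccco2)C(C(=O)c2ccc(C)cc2)S3)cc(OC)c1OC` gives 7500 nM. Compound 2 `COc1ccc(C(=O)C2Sc3nnc(-c4cc(OC)c(OC)c(OC)c4)n3NC2c2ccco2)cc1` in this assay reaches only the limit > 100000 nM, which is a limit of the assay and not a number (the limit of > 100000 nM in this assay, at which 1 of the 2 values shown sits). Within the data shown here, the one measured step, an at least 13-fold higher number from compound 1 to compound 2 (1.12 log units; beyond the scatter), changed the same aryl carbonyl and was large. Compound 3 `COc1cc(-c2nnc3n2NC(c2ccco2)C(C(=O)c2ccc(F)c(F)c2)S3)cc(OC)c1OC` differs from compound 2 by 3,4-difluorophenyl in place of 4-methoxyphenyl on a carbonyl carbon, again on that aryl carbonyl, so a large step back toward the number of compound 1 is expected, an at least 8.3-fold lower number from compound 2 to compound 3 (0.92 log units; beyond the scatter). Compound 3 is therefore estimated at 12000 nM, between 3000 nM and 100000 nM.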

Compound 3, half-maximal inhibitory concentration: 36000 nM
Compound 3: middle estimate off by 3.0-fold (0.48 log units), on the low side, within the range that was stated.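

On this carbonyl carbon, 3,4-difluorophenyl gives a measurable number where 4-methoxyphenyl did not, with an at least 2.7-fold lower number from compound 2 to compound 3 (0.44 log units; beyond the scatter). Compound 2 stands at a limit of the assay and not a number, so that step is only a bound: the limit of > 100000 nM in this assay, at which 1 of the 3 values shown sits. Set against 4-methylphenyl, the same group still gives the weaker result, with a 4.8-fold higher number from compound 1 to compound 3 (0.68 log units; beyond the scatter), so the 4-methylphenyl group remains the best of the three aryl groups shown. On these data alone, whether an unsubstituted phenyl or a 4-aminophenyl group at this carbonyl would match or better 4-methylphenyl stays open.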